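From propoxy to (thiophen-2-yl)oxy on the shared core

The source may report more compounds than this note shows. Statements on the series, on what has been measured and on what is new or still open speak of the compounds shown alone.

For the measured compounds named here, in a functional assay on KB cells (Homo sapiens) for cytotoxicity (on this read-out lower numbers stand for stronger inhibition and higher numbers for weaker inhibition), compound 1 `CCCOC1=CC(=O)c2ccccc2C1=O` gives 49400 nM, the highest number of the three measured so far. Compound 2 `O=C1C=CC(=O)c2c(Oc3ccco3)cccc21` gives 13400 nM, and compound 3 `CS(=O)(=O)Oc1ccc2c(c1)C(=O)C=CC2=O` gives 11600 nM. Both numbers lie below that of compound 1 by more than the scatter.

Compound 4 `O=C1C=C(Oc2cccs2)C(=O)c2ccccc21` has not yet been measured. It differs from compound 1 in one place, on an oxygen on an unsaturated carbon, where thiophen-2-yl stands in place of propyl: thiophen-2-yl in place of propyl on an oxygen on an unsaturated carbon. Going by the values given here, no step between measured compounds isolates this change, so the expectation rests on an indirect comparison. Compound 2 also has a five-membered aromatic ring with 1 hetero atom on an oxygen and gives 13400 nM, although it is not a one-place match for compound 1. In this assay, the expected step of a 3.3-fold lower number from compound 1 to compound 4 (0.52 log units; beyond the scatter) is toward a lower number and beyond the scatter. For compound 4 the estimated value is 15000 nM, with an expected range of 5000 nM to 40000 nM.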

Compound 4, half-maximal inhibitory concentration: 41500 nM
Beside the measured number, compound 4's estimate is 2.8-fold (0.44 log units) below it; measured number above the stated range.
By their numbers in this assay, from the lowest: compounds 3 and 2 (each within the scatter of the next); then compounds 4 and 1 (each within the scatter of the next).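

In this assay, for the compounds shown here, the first direct step at this place, on an oxygen on an unsaturated carbon, is flat: thiophen-2-yl in place of propyl gives a 1.2-fold lower number from compound 1 to compound 4 (0.08 log units; within the scatter). On the core of compound 1, this position therefore accepts a five-membered aromatic ring with 1 hetero atom in place of an open propyl chain with no change in the read-out beyond the scatter. Nothing available explains why this exchange leaves the number unchanged.

Going by these compounds, whether a different kind of group on this oxygen, such as an aminoethyl group, a phenyl ring or a longer alkyl chain like hexyl, would move the number remains open. So does whether the same exchange would stay flat on another core.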